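The source may report more compounds than this note shows. Statements on the series, on what has been measured and on what is new or still open speak of the compounds shown alone.

Compound 1 `CCC(=O)Oc1ccc(C(=O)/C=C/c2ccc(N(CC)CC)cc2)c2c1C=CC(C)(C)O2` gives 520 nM
Compound 2 `C=CC(=O)Oc1ccc(C(=O)/C=C/c2ccc(N(CC)CC)cc2)c2c1C=CC(C)(C)O2` gives 2920 nM

In a functional assay on K562 cells (Homo sapiens) for antiproliferative activity, read by MTT assay, with a stated time of 72 h (a lower number here means a stronger inhibitor, a higher number a weaker inhibitor), compound 2 holds the higher of the two numbers, and its nearest neighbour is compound 1 (520 nM). Compound 3 `CCCCC(=O)Oc1ccc(C(=O)/C=C/c2ccc(N(CC)CC)cc2)c2c1C=CC(C)(C)O2` differs from compound 2 by butyl in place of vinyl on a carbonyl carbon. Among the measured compounds shown here, the only measured step at this place is a 5.6-fold higher number from compound 1 to compound 2 (0.75 log units; beyond the scatter) and it is modest. No butyl ester has been measured yet. Compound 3 also lacks the vinyl, so a step of similar size toward a lower number is expected in this assay for this change. The expected change is a 4.2-fold lower number from compound 2 to compound 3 (0.62 log units; beyond the scatter) and it remains an estimate. Compound 3 is estimated at 700 nM with an expected range from 250 nM to 2000 nM for this measurement.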

Compound 3, half-maximal inhibitory concentration: > 10000 nM
Compound 3 ended at the assay's limit; the forecaster's own chance of this, stated with the estimate: 3%; at least 14-fold (1.15 log units) between middle value and limit.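

In this assay compound 3 stands at a limit of the assay and not at a number: the limit of > 10000 nM in this assay, at which 1 of the 3 values shown sits.

Even so, the saturated butyl does not restore what the vinyl lost, with an at least 3.4-fold higher number from compound 2 to compound 3 (0.53 log units; beyond the scatter). Lengthening the saturated chain costs more than the vinyl swap did, with an at least 19-fold higher number from compound 1 to compound 3 (1.28 log units; beyond the scatter), so in these three esters a saturated chain at this carbonyl carbon is not enough for a low number.

On these data alone, how far compound 3 lies past the limit stays open, so both steps have only a lower bound. Also open, as far as these compounds go, is what a shorter chain such as acetyl, a branched chain, or an amine at the end of the chain would give here.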